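A few compounds are considered here, and "the series" means these few. Any claim that something is new, unique, unknown or untested is made for them only; others in the source may bear on it.

Compound 1 `C[C@@H](C(=O)NC1CCCCC1)[C@H]1CC[C@@H](c2ccnc3ccc(F)cc32)CC1` carries a cyclohexylcarbamoyl group on the chain carbon next to the shared core. For the measured compounds named here, in an assay on tissue (M109 cells) for inhibition of Indoleamine 2,3-dioxygenase 1 (Mus musculus), with stated times of 2 h and 18 h (on this read-out higher numbers stand for weaker inhibition and lower numbers for stronger inhibition), compound 1 gives 287 nM, the highest of the three numbers so far. Compound 2 `C[C@@H](NC(=O)c1cccc(Cl)c1)[C@H]1CC[C@@H](c2ccnc3ccc(F)cc32)CC1` gives 48 nM and compound 3 `C[C@@H](NC(=O)C12CCC(Cl)(CC1)CC2)[C@H]1CC[C@@H](c2ccnc3ccc(F)cc32)CC1` gives 56 nM; both present the amide in the opposite sense, with the nitrogen on the chain carbon and the acyl group varied.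

Compound 4 `C[C@@H](NC(=O)C1CCCCC1)[C@H]1CC[C@@H](c2ccnc3ccc(F)cc32)CC1` is the unmeasured partner of compound 1: (cyclohexylcarbonyl)amino in place of cyclohexylcarbamoyl on a saturated chain carbon bound to a saturated chain carbon and a saturated ring carbon. This is a reversal of the amide, keeping the same atoms. Going by the values given here, only one step is measured, and it does not cross the amide: a 1.2-fold higher number from compound 2 to compound 3 (0.07 log units; within the scatter). It shows that exchanging the acyl group between an aromatic and a bicyclic ring left this assay unchanged within the scatter, so the acyl group seems to matter little among compounds 2 and 3. Among the compounds with values here, for the reversal itself no step exists; what is known is that compound 1 sits well above compounds 2 and 3, whose amides point the same way as that of compound 4.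

Compound 4 is therefore expected to move toward compounds 2 and 3, an estimated step of a 4.1-fold lower number from compound 1 to compound 4 (0.61 log units; beyond the scatter). The estimate for compound 4 is 70 nM, with a range from 25 nM to 200 nM.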

Compound 4, half-maximal inhibitory concentration: 86 nM
The estimate for compound 4 lay 1.2-fold (0.09 log units) below the measured number, within the range that was stated.
By their numbers in this assay, from the lowest: compounds 2, 3 and 4 (each within the scatter of the next); then compound 1.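

The amide reversal has now been measured directly in this assay (a 3.3-fold lower number from compound 1 to compound 4 (0.52 log units; beyond the scatter)): with the same atoms and the same cyclohexyl ring, the sense of the amide on this saturated chain carbon is enough to give a step beyond the scatter. With the nitrogen on the chain carbon, the acyl group can also be a plain cyclohexyl without a step beyond the scatter, as both comparisons within this amide sense show (a 1.8-fold higher number from compound 2 to compound 4 (0.25 log units; within the scatter); a 1.5-fold higher number from compound 3 to compound 4 (0.19 log units; within the scatter)), so compounds 2, 3 and 4 read alike in this assay across aromatic, bridged chlorinated and simple saturated rings on the carbonyl carbon. No supporting data accompany these numbers to account for the difference between the two amide senses.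

Going by these compounds, the effect of reversal rests on a single pair with a cyclohexyl group, so whether a step of similar size would appear with other ring groups remains open. Also open, on these data alone, is how far the tolerance on the carbonyl carbon extends, for instance to an acyl group carrying an amine or a carboxylic acid, or to a longer chain ending in the cyclohexyl ring.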